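Swapping the ester's benzyl for cyclopropylmethyl

A few compounds are considered here, and "the series" means these few. Any claim that something is new, unique, unknown or untested is made for them only; others in the source may bear on it.

Measured so far:
Compound 1 `CC1=C(C(=O)OCc2ccccc2)C(c2ccoc2)NC(=O)N1`: 6650 nM
Compound 2 `CC1=C(C(=O)OCc2ccccc2)C(c2cccs2)NC(=O)N1`: 1920 nM

In an assay on membranes from HEK293 cells for displacement of a labelled ligand from adenosine receptor A2b (Homo sapiens), read by scintillation counting, with a stated time of 30 min (on this read-out higher numbers stand for weaker inhibition and lower numbers for stronger inhibition), compound 2 gives 1920 nM, the lowest of the two numbers; the nearest is compound 1 at 6650 nM. For the measured compounds named here, the only measured step, a 3.5-fold lower number from compound 1 to compound 2 (0.54 log units; beyond the scatter), came from exchanging the group on the saturated ring carbon of the shared core. Compound 3 `CC1=C(C(=O)OCC2CC2)C(c2cccs2)NC(=O)N1` differs from compound 2 at a different place: cyclopropyl in place of phenyl on a saturated chain carbon bound to an oxygen next to a carbonyl group. Going by the values given here, no measured step touches this position, so the one known step does not bear on it and offers no direction. Given that, compound 3 is expected in this assay to land close to compound 2, a step of a 1.3-fold higher number from compound 2 to compound 3 (0.11 log units; within the scatter) that is best taken as none beyond the scatter. The estimate for compound 3 is 2500 nM, with a plausible range from 800 nM to 8000 nM.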

Compound 3, inhibition constant: 1570 nM
Compound 3: the middle estimate sits 1.6-fold (0.20 log units) above what was measured, and the stated range covers the measured number.
By their numbers in this assay, from the lowest: compounds 3 and 2 (each within the scatter of the next); then compound 1.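

In this assay, putting cyclopropyl in place of phenyl on a saturated chain carbon bound to an oxygen next to a carbonyl group gives a 1.2-fold lower number from compound 2 to compound 3 (0.09 log units; within the scatter), so this position now has a measured step, and the two compounds cannot be told apart. With thiophen-2-yl on the shared core, then, a six-membered aromatic ring is not required at this position to keep the number at this level: a three-membered non-aromatic ring with fewer heavy atoms serves equally well. No available evidence explains why the two groups read alike. Going by these compounds, whether the same swap holds with furan-3-yl on the saturated ring carbon remains open. Also open, on these data alone, is how this position responds to a longer straight chain or to a chain ending in an amine.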